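From compound 3 to compound 4: a changed aryl group

The source may hold more compounds than are shown below. What is called first, only, known or untested is meant among the compounds shown, and "the series" means these compounds.

In an ADME assay on microsomes from liver (Rattus norvegicus) for metabolic stability, read by LC-MS, using NADPH, at 37 degrees C (on this read-out lower numbers stand for a shorter-lived compound and higher numbers for a longer-lived compound), compound 3 `COc1cccc(F)c1-c1nc(CN2CCC(C(=O)NCCCN3C[C@H](C)C[C@H](C)C3)CC2)c(C)o1` gives 0.143 h and compound 1 `Cc1cccc(F)c1-c1nc(CN2CCC(C(=O)NCCCN3C[C@H](C)C[C@H](C)C3)CC2)c(C)o1` gives 0.0733 h. The gap between them, a 2.0-fold higher number from compound 1 to compound 3 (0.29 log units; within the scatter), does not separate them.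

Compound 2 `Cc1cccc(-c2nc(CN3CCC(C(=O)NCCCN4C[C@H](C)C[C@H](C)C4)CC3)c(C)o2)c1` reads > 0.5 h, which is a limit of the assay.

Compound 4 `Cc1cc(C)cc(-c2nc(CN3CCC(C(=O)NCCCN4C[C@H](C)C[C@H](C)C4)CC3)c(C)o2)c1` has 3,5-dimethylphenyl in place of 2-fluoro-6-methoxyphenyl on an aromatic carbon. Like compound 2, compound 4 lacks the fluoro and methoxy groups, though its second methyl group has no measured precedent. Going by the values given here, the steps that bear on this are an at least 6.8-fold higher number from compound 1 to compound 2 (0.83 log units; beyond the scatter) and an at least 3.4-fold lower number from compound 2 to compound 3 (0.54 log units; beyond the scatter), both beyond the scatter.

A rise beyond the scatter is therefore expected, a 3.1-fold higher number from compound 3 to compound 4 (0.50 log units; beyond the scatter). Compound 4 is estimated at 0.45 h, with an expected range of 0.2 h to 1 h.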

Compound 4, half-life: < 0.5 h
Compound 4 ended at the assay's limit (the forecaster's own chance of this, stated with the estimate: 50%); the middle value lies beyond the limit too.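

Compound 4 reads < 0.5 h in this assay, which is a limit and not a number. Adding a second methyl group to the aryl group at this position gives a number no higher from compound 2 to compound 4 (the limit leaves the size open), so it brings no gain over 3-methylphenyl, while the steps from compound 1 and compound 3 to compound 4 , like the size of this one, cannot be read.

Still open, on these data alone, are the actual half-life of compound 4 and where it stands against compound 1 and compound 3. Also open, as far as these compounds go, is how 3-chlorophenyl or 3-methoxyphenyl would read on this carbon.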